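Working notes: from compound 1 to compound 3

The source may report more compounds than this note shows. Statements on the series, on what has been measured and on what is new or still open speak of the compounds shown alone.

Measured in an in vitro ADME assay on microsomes from liver (Rattus norvegicus) for metabolic stability; on this read-out lower numbers stand for slow clearance and higher numbers for fast clearance:
- compound 1 `CC(C)NC(=O)[C@H]1CC[C@@H](n2/c(=N/C(=O)c3ccc(C#N)c(F)c3)[nH]c3ccc(CN4CCC(C(C)(C)O)CC4)cc32)CC1`: 29 mL.min-1.g-1
- compound 2 `CC(C)NC(=O)[C@H]1CC[C@@H](n2/c(=N/C(=O)c3ccccc3)[nH]c3ccc(CN4CCCCC4)cc32)CC1`: 389 mL.min-1.g-1

Compound 1 has the lower of the two numbers, and compound 2 lies higher by more than the scatter. Compound 3 `CC(C)NC(=O)[C@H]1CC[C@@H](n2/c(=N/C(=O)c3cc(F)cc(C#N)c3)[nH]c3ccc(CN4CCC(C(C)(C)O)CC4)cc32)CC1` carries 3-cyano-5-fluorophenyl in place of 4-cyano-3-fluorophenyl on a carbonyl carbon. Among the measured compounds shown here, no measured pair isolates this change, so the estimate rests on compound 1 at 29 mL.min-1.g-1. In this assay no change beyond the scatter is expected, the estimated step being a 1.1-fold higher number from compound 1 to compound 3 (0.04 log units; within the scatter). Compound 3 is expected at 32 mL.min-1.g-1, with an estimated range of 14 mL.min-1.g-1 to 75 mL.min-1.g-1.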

Compound 3, intrinsic clearance in microsomes: 30 mL.min-1.g-1
Estimate against measurement, compound 3: 1.1-fold (0.03 log units) above; low and high end bracket the measured number.
By their numbers in this assay, from the lowest: compounds 1 and 3 (each within the scatter of the next); then compound 2.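

In this assay, 3-cyano-5-fluorophenyl in place of 4-cyano-3-fluorophenyl on a carbonyl carbon gives a 1.0-fold higher number from compound 1 to compound 3 (0.01 log units; within the scatter). This first pair at this place shows that the read-out does not separate these two arrangements of the same atoms on the phenyl ring. No supporting data bear on this result.

Compound 2 differs from both compounds in more than one place, so the part played by the phenyl substituents remains unresolved. Also open, as far as these compounds go, is whether a trifluoromethyl group or a carboxylic acid in place of the nitrile would leave the read-out unmoved.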